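A few compounds are considered here, and "the series" means these few. Any claim that something is new, unique, unknown or untested is made for them only; others in the source may bear on it.

Compound 1 `CC(C)n1ncc2c(C(=O)N3CCc4cccnc43)cc(-c3cccs3)nc21` gives the only numbered result shown: in an ADME assay on LLC-MK2 cells (Macaca mulatta) for cytotoxicity, read by spectrophotometry and crystal violet staining, with a stated time of 4 days (on this read-out higher numbers stand for lower toxicity in this test and lower numbers for higher toxicity in this test), compound 1 gives 50000 nM. Compound 2 `CC(C)n1ccc2c(C(=O)Nc3ccccn3)cc(-c3cccs3)nc21` reaches a limit of the assay rather than a number: in this assay compound 2 gives > 200000 nM. Compound 3 `CC(C)n1ncc2c(C(=O)Nc3ccccn3)cc(-c3cccs3)nc21` is not yet measured; it differs from compound 1 by a group of 7 heavy atoms (5 carbon, 2 nitrogen; one six-membered aromatic ring with 1 hetero atom) in place of a group of 9 heavy atoms (7 carbon, 2 nitrogen; one five-membered non-aromatic ring with 1 hetero atom, one six-membered aromatic ring with 1 hetero atom), on a carbonyl carbon. No measured step between compounds differing in one place is shown. Compound 2 carries the same (pyridin-2-yl)amino group and sits at the limit of > 200000 nM in this assay, at which 1 of the 2 values shown sits, so a move toward lower toxicity is expected for compound 3. The expected step is a 3.0-fold higher number from compound 1 to compound 3 (0.48 log units; beyond the scatter). Compound 3 is expected to give 150000 nM, between 50000 nM and 300000 nM.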

Compound 3, half-maximal cytotoxic concentration: > 200000 nM
Compound 3 gave a limit, no number (the forecaster's own chance of this, stated with the estimate: 45%); at least 1.3-fold (0.12 log units) between middle value and limit.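

Replacing the group on the carbonyl carbon of compound 1 with (pyridin-2-yl)amino gives, in this assay, an at least 4.0-fold higher number from compound 1 to compound 3 (0.60 log units; beyond the scatter). This is the first measured step at this position, and the entering group carries a hydrogen-bond donor that the leaving group lacks, though nothing shown ties the step to that donor. Compound 3 gives a limit rather than a number, so the true size of the step stays unknown: the limit of > 200000 nM in this assay, at which 2 of the 3 values shown sit.

Going by these compounds, whether a phenylamino group or morpholine on the same carbonyl carbon would also reach this limit remains open. So does which part of the leaving group accounts for the lower number of compound 1.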